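Hydroxy for Methyl on a Slowly Cleared Core

A few compounds are considered here, and "the series" means these few. Any claim that something is new, unique, unknown or untested is made for them only; others in the source may bear on it.

Compound 2, `CCc1nc(N)nc2c1c(-c1ccc3oc(N)nc3c1)nn2C(C)C`, stands at the floor of what an ADME assay on cells (Hepatocyte, Homo sapiens) for metabolic stability, read by LC-MS, with a stated time of 90 min, tested at 1 uM (on this read-out lower numbers stand for slow clearance and higher numbers for fast clearance), can report. In this assay compound 2 gives < 5 uL/min, which is a limit of the assay rather than a number. Compound 1, `Cc1nc(N)nc2c1c(-c1ccc3oc(N)nc3c1)nn2C(C)C`, shares the same core. In this assay compound 1 likewise gives < 5 uL/min, again a limit. Within the data shown here, the only step between measured compounds, a step that the two limits leave unreadable from compound 1 to compound 2, cannot be read in size, so it offers no guide. Both values sit at the same place, (the limit of < 5 uL/min in this assay, at which 2 of the 2 values shown sit).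

The unmeasured compound 3, `CC(C)n1nc(-c2ccc3oc(N)nc3c2)c2c(CO)nc(N)nc21`, differs from compound 2 by hydroxy in place of methyl on a saturated chain carbon bound to an aromatic carbon. Among the measured compounds shown here, no measured step bears on this change, so the expectation rests only on where compound 2 stands. The step that the limit leaves unreadable from compound 2 to compound 3 is expected to stay within the usual scatter. Compound 3 is estimated at 4 uL/min, with a range from 2 uL/min to 10 uL/min, and most likely reported as a limit once more.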

Compound 3, intrinsic clearance in a liver preparation (reported as CLH), per the amount of preparation that the assay uses: < 5 uL/min
Compound 3: no number, only a limit (the forecaster's own chance of this, stated with the estimate: 65%); the middle value lies beyond the limit too.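

No step among compound 1, compound 2 and compound 3 can be read in this assay, because all three stop at the same limit of the assay rather than giving a number: the limit of < 5 uL/min in this assay, at which 3 of the 3 values shown sit.

From the compounds shown here alone, how far their true clearances lie apart, and whether hydroxy in place of methyl changes clearance at all, stays open.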